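The compounds below may be only part of what the source reports. "The series", "measured", "known", "first", "only" and "open" are said of these compounds alone.

Measured so far:
compound 1 `CNCCNCc1cccc(-c2nc(NC3CCOCC3)c(C)c(-c3ccncc3)n2)c1`: 44300 nM
compound 2 `CNCCNCc1cccc(-c2nc(-c3c(C)noc3C)c(C)c(N3CCN(S(C)(=O)=O)CC3)n2)c1`: a limit, > 50000 nM

Going by the values given here, in a functional assay on A-375 cells (Homo sapiens) for inhibition, read by sulforhodamine B assay, with a stated time of 6 days (on this read-out lower numbers stand for stronger inhibition and higher numbers for weaker inhibition), compound 1 gives 44300 nM, the only plain number obtained, and a weak inhibitor. Compound 2 reaches only a limit of this assay, > 50000 nM, which is the limit of > 50000 nM in this assay, at which 1 of the 2 values shown sits. Compound 3 `CNCCNCc1cccc(-c2nc(NC3CCOCC3)c(C)c(-c3c(C)nn(C)c3C)n2)c1` is still to be measured. It differs from compound 1 in one place: 1,3,5-trimethyl-1H-pyrazol-4-yl in place of pyridin-4-yl on an aromatic carbon. Among the compounds with values here, no measured step between compounds exists here, so the data give no direction. The step of a 1.1-fold higher number from compound 1 to compound 3 (0.05 log units; within the scatter) is expected to be none beyond the scatter, given how weak compound 1 already is at 44300 nM. Compound 3 is estimated at 50000 nM, between 15000 nM and 150000 nM, with a real chance that only a limit is reported.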

Compound 3, half-maximal inhibitory concentration: > 50000 nM
Compound 3 ended at the assay's limit; the forecaster's own chance of this, stated with the estimate: 55%; the middle value sits exactly at the limit.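

Putting 1,3,5-trimethyl-1H-pyrazol-4-yl in place of pyridin-4-yl at this position gives an at least 1.1-fold higher number from compound 1 to compound 3 (0.05 log units; that floor lies within the scatter) in this assay. The value of compound 3 is a limit, so this step is only a floor, and the change brings no measurable gain in inhibition. With this change, most of the compounds shown now sit at the edge of what the assay can read: the limit of > 50000 nM in this assay, at which 2 of the 3 values shown sit.

Going by these compounds, the true size of this step stays open. So does whether a plain phenyl ring or a primary amine at this position would bring inhibition clear of that limit.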